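The source may hold more compounds than are shown below. What is called first, only, known or untested is meant among the compounds shown, and "the series" means these compounds.

Measured so far in an ADME assay on HeLa cells (Homo sapiens) for cytotoxicity, read by sulforhodamine B assay, with a stated time of 48 h, tested at 10 uM; a lower number here means less inhibition, a higher number more inhibition at the concentration tested (going by the name of the read-out):
compound 1 `COc1nc2ccc(Br)cc2cc1C(c1ccccc1)n1cc(C2CC2)nn1`: -5.84%
compound 2 `CCCCCCCc1cn(C(c2ccccc2)c2cc3cc(Br)ccc3nc2OC)nn1`: 9.7%
compound 3 `COc1nc2ccc(Br)cc2cc1C(c1ccccc1)n1cc(CO)nn1`: 0.25%

Compound 3 holds the second highest of the three numbers; its nearest neighbour is compound 1, with a number 6.1 percentage points higher from compound 1 to compound 3 (within the scatter), and its furthest is compound 2, with a number 9.5 percentage points lower from compound 2 to compound 3 (within the scatter), both within the scatter. Compound 4 `COc1nc2ccc(Br)cc2cc1C(c1ccccc1)n1cc(-c2ccccc2)nn1` differs from compound 3 by phenyl in place of hydroxymethyl on an aromatic carbon. Among the compounds with values here, the only step at this position that lies beyond the scatter is a number 15.5 percentage points higher from compound 1 to compound 2 (beyond the scatter), where the larger heptyl group carried the higher number; the two steps involving hydroxymethyl stayed within the scatter. Phenyl is a larger group entering at the same aromatic carbon, so a small rise is expected, a number 6.8 percentage points higher from compound 3 to compound 4 (within the scatter), though likely within the scatter. Compound 4 is estimated at 7%, range -8% to 22%.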

Compound 4, a percentage reported as inhibition, at one concentration (the size of the read-out at that concentration, not a potency): 13.9%
For compound 4 the middle estimate is 6.9 percentage points below the measured one, and the stated range covers the measured number.
By their numbers in this assay, from the lowest: compounds 1, 3, 2 and 4 (each within the scatter of the next, the first and the last beyond it).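

In this assay, phenyl at this aromatic carbon gives a number 13.7 percentage points higher from compound 3 to compound 4 (beyond the scatter), the first step from hydroxymethyl at this position to lie beyond the scatter, and a number 19.7 percentage points higher from compound 1 to compound 4 (beyond the scatter), so an aromatic ring joins heptyl in standing clear of cyclopropyl. Against heptyl, phenyl gives a number 4.2 percentage points higher from compound 2 to compound 4 (within the scatter), which leaves the two groups unseparated. Nothing measured here accounts for these steps. Open, from the compounds shown here alone, is whether a substituted phenyl, a pyridine ring, an amine or a carboxylic acid at this carbon would follow phenyl or hydroxymethyl.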